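Swapping Methoxy for Chloro on a Shared Core

The compounds below may be only part of what the source reports. "The series", "measured", "known", "first", "only" and "open" are said of these compounds alone.

Of the compounds shown here, three built on one shared core have been tested in a functional assay on A498 cells (Homo sapiens) for inhibition; a higher number here means a weaker inhibitor of growth, a lower number a stronger inhibitor of growth. Compound 1 `COc1cc(/C=C/C(=O)c2cccc(-n3cc(-c4ccccc4)[nH]c3=O)c2)ccc1O` gives 1680 nM. Compound 2 `O=C(/C=C/c1cccc(O)c1)c1cccc(-n2cc(-c3ccc(Cl)cc3)[nH]c2=O)c1` gives 3710 nM. Compound 3 `COc1ccc(-c2cn(-c3cccc(C(=O)/C=C/c4ccc(O)c(OC)c4)c3)c(=O)[nH]2)cc1` gives 3720 nM, the highest of the three numbers; its gap to compound 2 lies within the scatter, while a 2.2-fold higher number from compound 1 to compound 3 (0.35 log units; beyond the scatter) places it beyond the scatter from compound 1.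

Compound 4 `COc1cc(/C=C/C(=O)c2cccc(-n3cc(-c4ccc(Cl)cc4)[nH]c3=O)c2)ccc1O` has not yet been measured. It differs from compound 3 by chloro in place of methoxy on an aromatic carbon. Among the measured compounds shown here, one measured step touches the same site: a 2.2-fold higher number from compound 1 to compound 3 (0.35 log units; beyond the scatter), a modest rise when methoxy entered in place of hydrogen. For the measured compounds named here, for chloro at this site no direct step exists. Compound 2 carries the same chloro group, but its other aromatic ring also differs, so its value of 3710 nM only hints that chloro here need not bring a strong inhibitor.

Taking the methoxy away points back toward compound 1, and the untested chloro adds uncertainty. A modest fall in this assay is therefore expected for compound 4, a 1.6-fold lower number from compound 3 to compound 4 (0.21 log units; within the scatter), close to the edge of the scatter. Compound 4 is estimated at 2300 nM, within a range from 900 nM to 5500 nM.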

Compound 4, concentration for 50% growth inhibition: 2820 nM
Beside the measured number, compound 4's estimate is 1.2-fold (0.09 log units) below it, within the range that was stated.
By their numbers in this assay, from the lowest: compounds 1, 4, 2 and 3 (each within the scatter of the next, the first and the last beyond it).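

In this assay, replacing 4-methoxyphenyl with 4-chlorophenyl gives a step that stays within the scatter (a 1.3-fold lower number from compound 3 to compound 4 (0.12 log units; within the scatter)), so the two groups cannot be told apart at this carbon, para to a large group. Hydrogen at the same carbon now has two comparisons: the step to methoxy stands beyond the scatter (a 2.2-fold higher number from compound 1 to compound 3 (0.35 log units; beyond the scatter)), while the step to chloro does not (a 1.7-fold higher number from compound 1 to compound 4 (0.22 log units; within the scatter)), so only methoxy gives a clear change from hydrogen, and a modest one. With chloro held in place, replacing 3-hydroxyphenyl with 4-hydroxy-3-methoxyphenyl on the other side of the molecule also gives no change that can be read (a 1.3-fold lower number from compound 2 to compound 4 (0.12 log units; within the scatter)), so compound 2 and compound 4 cannot be separated in this assay.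

On these data alone, the four compounds carry only hydrogen, methoxy or chloro at this carbon, so how an amine or a carboxylic acid there would read in this assay remains open. Why these steps are so small also remains open, as no measurement here bears on it.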